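Working notes on the series, compounds 1 to 3

A few compounds are considered here, and "the series" means these few. Any claim that something is new, unique, unknown or untested is made for them only; others in the source may bear on it.

Measured so far:
compound 1, `CCCCCNC(=O)NS(=O)(=O)c1cc(C#N)ccc1Oc1ccc(C)cc1`, 630 nM
compound 2, `CCCCCNC(=O)NS(=O)(=O)c1cc(C#N)ccc1Oc1ccc(F)cc1`, 9530 nM

Both numbers come from a functional assay on HEK293 cells for antagonist activity at thromboxane A2 receptor (Homo sapiens), read by fluorescence and calcium flux; on this read-out higher numbers stand for weaker inhibition and lower numbers for stronger inhibition. Going by the values given here, compound 2 stands highest of the two; its only neighbour is compound 1, and the step of a 15-fold higher number from compound 1 to compound 2 (1.18 log units; beyond the scatter) lies beyond the scatter, so the two compounds are clearly separated on this read-out.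

Compound 3, `CCCCCNC(=O)NS(=O)(=O)c1cc(C#N)ccc1Nc1ccc(F)cc1`, has not been measured. It differs from compound 2 in one place: (4-fluorophenyl)amino in place of 4-fluorophenoxy on an aromatic carbon. Among the compounds with values here, no measured step bears on this change. Within the data shown here, the single step in hand, a 15-fold higher number from compound 1 to compound 2 (1.18 log units; beyond the scatter), concerns fluoro in place of methyl and says nothing about the group that carries the second ring. With nothing to argue a direction, the working expectation is that compound 3 stays close to compound 2, with the step of a 1.6-fold lower number from compound 2 to compound 3 (0.20 log units; within the scatter) expected to fall within the scatter, but the range must be kept wide. Compound 3 is therefore estimated at 6000 nM, expected between 1200 nM and 30000 nM.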

Compound 3, half-maximal inhibitory concentration: 6450 nM
The estimate for compound 3 lay 1.1-fold (0.03 log units) below the measured number; low and high end bracket the measured number.
By their numbers in this assay, from the lowest: compound 1; then compounds 3 and 2 (each within the scatter of the next).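

Replacing 4-fluorophenoxy with (4-fluorophenyl)amino on this aromatic carbon, ortho to a large group and para to a cyano group, gives no change that can be resolved in this assay (a 1.5-fold lower number from compound 2 to compound 3 (0.17 log units; within the scatter)), even though the entering group carries a hydrogen-bond donor that the leaving group lacks. The larger step to the amino compound (a 10-fold higher number from compound 1 to compound 3 (1.01 log units; beyond the scatter)) replaces 4-methylphenoxy as a whole, so it cannot be divided between the loss of methyl and the new amino link, yet both fluoro compounds now stand clearly apart from the methyl compound 1, with neither going against this among the three compounds. Nothing in hand explains either step.

On these data alone, whether (4-methylphenyl)amino would restore the lower number of compound 1 remains open, which leaves the two changes unseparated with the amino link in place. Also open, as far as these compounds go, is how a methylated amine nitrogen, a sulfur or a methylene in the same linking role would read, and how a chloro or methoxy group would compare with methyl and fluoro on the second ring.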